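Replacing a methoxy with a hydroxy on a weak compound

A few compounds are considered here, and "the series" means these few. Any claim that something is new, unique, unknown or untested is made for them only; others in the source may bear on it.

Measured in a functional assay on A549 cells (Homo sapiens) for cytotoxicity, read by MTT assay, with a stated time of 72 h; on this read-out lower numbers stand for stronger inhibition and higher numbers for weaker inhibition:
Compound 1 `COc1ccc(/C=C2\CCC/C(=C\c3ccc(Br)cc3)C2=O)cc1OC`: 16000 nM
Compound 2 `COc1cccc(/C=C2\CCC/C(=C\c3ccc(OC)c(OC)c3)C2=O)c1`: 6700 nM
Compound 3 `COc1ccc(/C=C2\CCC/C(=C\c3ccc(OC)c(OC)c3)C2=O)cc1`: > 20000 nM (a limit)

Compound 3 has no exact number, and its > 20000 nM is only a limit of the assay.

Compound 4 `COc1ccc(/C=C2\CCC/C(=C\c3ccc(O)cc3)C2=O)cc1OC` has not yet been measured. It differs from compound 3 in one place: hydrogen in place of methyl on an oxygen on an aromatic ring. This is hydrogen in place of methyl on an oxygen on an aromatic ring, so methoxy becomes hydroxy.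

Within the data shown here, no measured pair makes this exact change, so the evidence is indirect. The closest is methoxy in place of bromo on an aromatic carbon, which gave an at least 1.2-fold higher number from compound 1 to compound 3 (0.09 log units; that floor lies within the scatter). Shifting a single methoxy gave an at least 2.9-fold higher number from compound 2 to compound 3 (0.47 log units; beyond the scatter), and exchanging a whole aryl group gave a 2.4-fold lower number from compound 1 to compound 2 (0.38 log units; beyond the scatter). Small edits to these outer rings have therefore given modest steps at most.

A modest step toward a lower number is expected in this assay, into the region where compound 2 gives 6700 nM and compound 1 gives 16000 nM. The expected change is an at least 2.0-fold lower number from compound 3 to compound 4 (0.30 log units; that floor lies within the scatter). For compound 4 the estimated value is 10000 nM, with an expected range of 3500 nM to 20000 nM.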

Compound 4, half-maximal inhibitory concentration: > 20000 nM
Compound 4: no number, only a limit; the forecaster's own chance of this, stated with the estimate: 25%; at least 2.0-fold (0.30 log units) between middle value and limit.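

Hydroxy on this aromatic ring leaves compound 4 at a limit in this assay, just as methoxy left compound 3 at one, so the step between the two cannot be read and no gain from freeing this oxygen shows up: the limit of > 20000 nM in this assay, at which 2 of the 4 values shown sit.

The comparison with the more active 3-methoxyphenyl compound can still be read, as the swap to 4-hydroxyphenyl gives an at least 2.9-fold higher number from compound 2 to compound 4 (0.47 log units; beyond the scatter), so this hydroxy compound does not reach that level. The comparison with the bromo compound says much less, since hydroxy in place of bromo gives an at least 1.2-fold higher number from compound 1 to compound 4 (0.09 log units; that floor lies within the scatter), and that does not separate the two groups.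

On these data alone, what stays open is whether methoxy and hydroxy differ at all on this ring, as the true values of compound 3 and compound 4 are hidden behind the same limit. As far as these compounds go, it is also open whether an amine or a carboxylic acid on this aromatic carbon, or a longer chain such as ethoxy or propoxy on this oxygen, would give a measurable value in this assay.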